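A few compounds are considered here, and "the series" means these few. Any claim that something is new, unique, unknown or untested is made for them only; others in the source may bear on it.

Of the compounds shown here, three sharing one core have been tested in an ADME assay on L6 cells (Rattus norvegicus) for cytotoxicity, read by resazurin assay, with a stated time of 72 h; a higher number here means a weaker inhibitor, a lower number a stronger inhibitor. Compound 1 `N#Cc1ccc(C(O)(c2ccc(C(F)(F)F)cc2)c2cccnc2)cc1` gives 76500 nM, and compound 2 `N#Cc1ccc(C(O)(c2ccc(C(F)(F)F)cc2)c2cccnc2)c(F)c1` gives 56100 nM. Compound 3 `NC(=O)c1ccc(C(O)(c2ccc(C(F)(F)F)cc2)c2cccnc2)cc1` gives > 100000 nM, which is a limit of the assay and not a number. That places compound 3 at the limit of > 100000 nM in this assay, at which 1 of the 3 values shown sits, so its true position is not known.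

The next structure, compound 4 `OC(c1ccc(C(F)(F)F)cc1)(c1cccnc1)c1cc2ccccc2s1`, changes one group of compound 3: 1-benzothiophen-2-yl in place of 4-carbamoylphenyl, on a saturated chain carbon bound to two aromatic carbons and an oxygen on a saturated carbon (1-benzothiophen-2-yl in place of 4-carbamoylphenyl on a saturated chain carbon bound to two aromatic carbons and an oxygen on a saturated carbon).

Among the measured compounds shown here, no tested compound carries this new group, so the measured steps offer only indirect guidance. The closest is the change at that same carbon, an at least 1.7-fold higher number from compound 2 to compound 3 (0.25 log units; that floor lies within the scatter). Two changes elsewhere are a 1.4-fold lower number from compound 1 to compound 2 (0.13 log units; within the scatter) and an at least 1.3-fold higher number from compound 1 to compound 3 (0.11 log units; that floor lies within the scatter). All three stay within the scatter, so none of them points to a large effect in this assay.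

A small move toward a lower number is therefore expected, bringing compound 4 near the values of compound 1 and compound 2. The expected change is an at least 2.0-fold lower number from compound 3 to compound 4 (0.30 log units; that floor lies within the scatter). For compound 4 the estimated value is 50000 nM, with an expected range of 20000 nM to 100000 nM.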

Compound 4, half-maximal inhibitory concentration: 58700 nM
Estimate against measurement, compound 4: 1.2-fold (0.07 log units) below, and the stated range covers the measured number.
By their numbers in this assay, from the lowest: compounds 2, 4 and 1 (each within the scatter of the next). At a limit, above all of these: compound 3.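

Until now, every group tested on this saturated chain carbon was a substituted phenyl ring; compound 4 shows that 1-benzothiophen-2-yl, with its five-membered aromatic ring and neither a nitrile nor a carbamoyl group, can stand there with no real shift in this assay. Replacing 4-cyano-2-fluorophenyl gives a 1.0-fold higher number from compound 2 to compound 4 (0.02 log units; within the scatter), and replacing 4-cyanophenyl gives a 1.3-fold lower number from compound 1 to compound 4 (0.12 log units; within the scatter), so among these three compounds neither the nitrile nor the benzene ring at this carbon is needed for a number in this range, while the step from the carbamoyl compound, an at least 1.7-fold lower number from compound 3 to compound 4 (0.23 log units; that floor lies within the scatter), can be read only as a floor. Compound 3 remains a limit of the assay and not a number: the limit of > 100000 nM in this assay, at which 1 of the 4 values shown sits.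

On these data alone, the true size of the gap between 1-benzothiophen-2-yl and 4-carbamoylphenyl stays unknown, and so does the effect of a group such as an amine or a carboxylic acid on the ring at this carbon. As far as these compounds go, the rest of the shared core is the same in all four compounds, so what changes at any other position would do remains open.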